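What to Expect of Compound 4

The source may hold more compounds than are shown below. What is called first, only, known or untested is meant among the compounds shown, and "the series" means these compounds.

In an ADME assay on microsomes from liver (Homo sapiens) for metabolic stability, read by LC-MS, with a stated time of 10 min, tested at 0.5 uM (a higher number here means that more of the compound is left, a lower number that less of the compound is left), compound 1 `c1ccc2c(c1)CN[C@@H](CN(CC1CCNCC1)[C@H]1CCCc3cccnc31)C2` gives 86%, compound 3 `c1ccc2c(c1)CN[C@@H](CN(CCC1CCNCC1)[C@H]1CCCc3cccnc31)C2` gives 66%, and compound 2 `c1ccc2c(c1)CN[C@H](CN(CCCN1CCNCC1)[C@H]1CCCc3cccnc31)C2` gives 99%. Compound 2 thus stands highest of the three, beyond the scatter from both others.

Compound 4 `c1cnc2c(c1)CCC[C@@H]2N(CCCN1CCNCC1)Cc1cc2ccccc2cn1` has not yet been measured. It differs from compound 2 in one place: isoquinolin-3-yl in place of 1,2,3,4-tetrahydroisoquinolin-3-yl on a saturated chain carbon bound to an amine nitrogen. In words, isoquinolin-3-yl stands in place of 1,2,3,4-tetrahydroisoquinolin-3-yl on a saturated chain carbon bound to an amine nitrogen.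

Within the data shown here, no measured step touches this group. The only one available, a number 20 percentage points lower from compound 1 to compound 3 (beyond the scatter), exchanges piperidin-4-yl for (piperidin-4-yl)methyl elsewhere, so it serves only as a rough guide to size. A fall of similar, modest size is the likelier outcome because compound 2 already stands at 99%, which leaves little room for a rise. The expected change is a number 19 percentage points lower from compound 2 to compound 4 (beyond the scatter). For compound 4 the estimated value is 80%, with an expected range from 55% to 98%.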

Compound 4, percent of the compound remaining: 66%
Compound 4: the middle estimate sits 14 percentage points above what was measured, within the range that was stated.
By their numbers in this assay, from the lowest: compounds 3 and 4 (each within the scatter of the next); then compound 1; then compound 2.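

Among these compounds, the step of a number 33 percentage points lower from compound 2 to compound 4 (beyond the scatter) in this assay is the first reading at this position, and it shows that the number responds to this group on a saturated chain carbon bound to an amine nitrogen, not only to the chain changed in the earlier step. The exchange is large even though the heavy atoms stay the same in number and kind: the non-aromatic ring becomes aromatic, and the hydrogen-bond donor and the defined stereocentre both go. Nothing available explains the fall or shows which of these differences matters.

The compounds shown leave open whether a single-ring group such as pyridin-2-yl would give a number closer to that of compound 2 or compound 4. They also leave open whether the same exchange would cost as much with the piperidin-4-yl or (piperidin-4-yl)methyl chains.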